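The source may hold more compounds than are shown below. What is called first, only, known or untested is meant among the compounds shown, and "the series" means these compounds.

Compound 1 `Fc1cccc(-c2nc(Nc3ccccc3F)c3cc(F)ccc3n2)c1` — in a functional assay on COLO 205 cells (Homo sapiens) for cytotoxicity, read by MTT assay, with a stated time of 48 h (on this read-out higher numbers stand for weaker inhibition and lower numbers for stronger inhibition), compound 1 reaches only the limit > 50000 nM.
Compound 2 `Fc1cccc(-c2nc(Nc3ccc(Cl)cc3)c3cc(F)ccc3n2)c1` — in this assay compound 2 gives 32600 nM.
Compound 3 `Fc1cccc(-c2nc(Nc3ccc(Br)cc3)c3cc(F)ccc3n2)c1` — in this assay compound 3 reaches only the limit > 50000 nM.

Compound 3 therefore stands at the top of the measured range, one of the values at the limit of > 50000 nM in this assay, at which 2 of the 3 values shown sit. Compound 4 `Oc1cccc(Nc2nc(-c3cccc(F)c3)nc3ccc(F)cc23)c1` differs from it by 3-hydroxyphenyl in place of 4-bromophenyl on a nitrogen on an aromatic ring. Among the compounds with values here, no measured step touches a hydroxyl group; the steps known, an at least 1.5-fold lower number from compound 1 to compound 2 (0.18 log units; that floor lies within the scatter) and an at least 1.5-fold higher number from compound 2 to compound 3 (0.18 log units; that floor lies within the scatter), are within the scatter, and a step that the two limits leave unreadable from compound 1 to compound 3 cannot be read. Within the data shown here, the three compounds so far sit close to or at the limit, so no step beyond the scatter is expected in this assay. Compound 4 is estimated at 40000 nM, between 12000 nM and 100000 nM. From compound 3 this means an expected step of an at least 1.2-fold lower number from compound 3 to compound 4 (0.09 log units; that floor lies within the scatter).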

Compound 4, half-maximal inhibitory concentration: > 50000 nM
Compound 4 ended at the assay's limit; the forecaster's own chance of this, stated with the estimate: 50%; middle value at least 1.2-fold (0.09 log units) from the limit.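

In this assay compound 4, with 3-hydroxyphenyl and its hydrogen-bond donor on the nitrogen in place of 4-bromophenyl, also stays at a limit, which is not a number: the limit of > 50000 nM in this assay, at which 3 of the 4 values shown sit.
The step of an at least 1.5-fold higher number from compound 2 to compound 4 (0.18 log units; that floor lies within the scatter) is the only one that can be read; the steps to compound 4 from compound 1 and from compound 3 cannot be read, as each joins two limits.
The compounds shown leave open whether a phenyl ring carrying an amine or a carboxylic acid on this nitrogen would give a number clear of the limit.
They also leave open whether changes elsewhere on the shared core would do so.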